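A few compounds are considered here, and "the series" means these few. Any claim that something is new, unique, unknown or untested is made for them only; others in the source may bear on it.

Three compounds that share one core were examined in an assay on isolated protein for inhibition of 3',5'-cyclic-AMP phosphodiesterase 4A (Cavia porcellus), read by cAMP accumulation, tested at 1 uM; on this read-out lower numbers stand for a weaker effect and higher numbers for a stronger effect at the one concentration tested. Compound 1 `CC(=O)c1cc(C(=O)c2ccccc2)c(=O)[nH]c1C` gives 0% in this assay. Compound 2 `O=C(c1ccccc1)c1cc(C(=O)c2ccccc2)c(=O)[nH]c1-c1ccccc1` gives 0%, and compound 3 `O=C1CCCc2[nH]c(=O)c(C(=O)c3ccccc3)cc21` gives 0%. Compound 2 thus stands level with compound 1 and with compound 3 at the digits reported; all three values lie within the usual scatter of one another, so none of them can be told apart on this read-out, and every one sits at the bottom of the scale.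

Compound 4 `O=C(c1ccccc1)c1cc(S(=O)(=O)c2ccccc2)c(=O)[nH]c1-c1ccccc1` has not yet been measured. It differs from compound 2 in a single place: phenylsulfonyl in place of benzoyl on an aromatic carbon. Going by the values given here, no step between two measured compounds shows what this kind of exchange does on this read-out. With all three measured values at the floor and the rest of the structure unchanged, the expected step of a number 2 percentage points higher from compound 2 to compound 4 (within the scatter) is one of little size, in no clear direction beyond the scatter. Compound 4 is therefore estimated at 2%, with a range from 0% to 15%.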

Compound 4, a percentage reported as inhibition, at one concentration (the size of the read-out at that concentration, not a potency): 0%
The estimate for compound 4 lay 2 percentage points above the measured number, and the stated range covers the measured number.
By their numbers in this assay, from the lowest: compounds 1, 2, 3 and 4 (each within the scatter of the next).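

Phenylsulfonyl in place of benzoyl on an aromatic carbon gives no change at the digits printed from compound 2 to compound 4 (within the scatter) in this assay, the first step shown at this position. The exchange adds a sulfur atom and a second hydrogen-bond acceptor while keeping the six-membered aromatic ring, yet it does not lift the read-out off the bottom of the scale; compound 2 already sits there, so this step could reveal a gain but not a loss. No measurement on hand offers an explanation for this result.

The compounds shown leave open whether an amine or a carboxylic acid on this aromatic carbon would raise the read-out above the floor. They also leave open what phenylsulfonyl would do in a compound that starts with a measurable effect.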